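Changing the Amide Substituent of Compound 2

This account rests on a few compounds, and the source may have more. Where it says the series, first, only, none or still open, it means among the compounds named here.

In an ADME assay on microsomes from liver (Mus musculus, strain CD-1) for metabolic stability, read by LC-MS, tested at 2 uM (on this read-out higher numbers stand for a longer-lived compound and lower numbers for a shorter-lived compound), compound 1 `CNC(=O)c1ccncc1Nc1cc(-c2ccc3ccn(C)c3c2)c2nccnc2c1` gives 0.45 h, and compound 2 `Cn1cc(CNC(=O)c2ccncc2Nc2cc(-c3ccc4ccn(C)c4c3)c3nccnc3c2)cn1` gives 0.267 h. These two values lie within the usual scatter of each other, so the numbers do not separate compound 2 from compound 1.

Compound 3 `CN1CCC(NC(=O)c2ccncc2Nc2cc(-c3ccc4ccn(C)c4c3)c3nccnc3c2)CC1` has not yet been measured. It keeps the shared core and differs from compound 2 on an amide-type nitrogen: 1-methylpiperidin-4-yl in place of (1-methyl-1H-pyrazol-4-yl)methyl on an amide-type nitrogen. One five-membered aromatic ring therefore leaves, and one six-membered non-aromatic ring enters.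

Going by the values given here, only one measured step touches this part of the molecule: a 1.7-fold lower number from compound 1 to compound 2 (0.23 log units; within the scatter). That step placed 1-methyl-1H-pyrazol-4-yl on a saturated chain carbon bound to the amide-type nitrogen. Among the compounds with values here, it is a single example, and no measured compound carries the 1-methylpiperidin-4-yl group, so the evidence is thin. Since that one step stayed within the scatter, no step beyond the scatter is expected here.

In this assay the estimated step is a 1.1-fold higher number from compound 2 to compound 3 (0.05 log units; within the scatter). Compound 3 is expected to give about 0.3 h, with an estimated range from 0.13 h to 0.7 h.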

Compound 3, half-life: > 1 h
Compound 3: no number, only a limit; the forecaster's own chance of this, stated with the estimate: 3%; middle value at least 3.3-fold (0.52 log units) away from the limit.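

The value of compound 3 in this assay is a limit of the assay and not a number: the limit of > 1 h in this assay, at which 1 of the 3 values shown sits.

Even so, it shows that the group on this amide-type nitrogen can move the half-life by more than the scatter, which the earlier pair could not show, since a 1.7-fold lower number from compound 1 to compound 2 (0.23 log units; within the scatter) stayed within it: putting 1-methylpiperidin-4-yl in place of (1-methyl-1H-pyrazol-4-yl)methyl gives an at least 3.7-fold higher number from compound 2 to compound 3 (0.57 log units; beyond the scatter). The same group in place of methyl gives an at least 2.2-fold higher number from compound 1 to compound 3 (0.34 log units; beyond the scatter), so compound 3 stands clear of both earlier compounds, and the two groups exchanged in the first of these steps have the same count of heavy atoms, so that count does not tell them apart.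

On these data alone, how far compound 3 really lies beyond the other two stays unknown, and so does the feature of the 1-methylpiperidin-4-yl group that goes with the longer half-life. A piperidin-4-yl group without its methyl, or a cyclohexyl ring with no nitrogen at all, would show whether the ring nitrogen and its methyl matter or whether the saturated six-membered ring alone is enough.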